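Swapping Fluoro for Methoxy: What Growth Inhibition to Expect

The source may hold more compounds than are shown below. What is called first, only, known or untested is meant among the compounds shown, and "the series" means these compounds.

Measured compounds:
Compound 1, `CO/N=C(/COc1ccc2c(=O)cc(-c3ccccc3)oc2c1)c1ccccc1`, gives 2000000 nM in a functional assay on SK-HEP1 cells (Homo sapiens) for antiproliferative activity; on this read-out lower numbers stand for stronger inhibition of growth and higher numbers for weaker inhibition of growth.
Compound 2, `CO/N=C(/COc1ccc2c(=O)cc(-c3ccccc3)oc2c1)c1ccc(F)cc1`, gives 3300000 nM in this assay.

Compound 2 stands at the higher of the two numbers, and the step of a 1.7-fold higher number from compound 1 to compound 2 (0.22 log units; within the scatter) lies within the scatter, so the two measured compounds cannot be told apart on this read-out. Both numbers are very high, meaning only weak inhibition of growth.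

Compound 3, `CO/N=C(/COc1ccc2c(=O)cc(-c3ccccc3)oc2c1)c1ccc(OC)cc1`, differs from compound 2 by methoxy in place of fluoro on an aromatic carbon. For the measured compounds named here, only one measured step bears on this change, and it was within the scatter; it concerned fluoro in place of hydrogen, not methoxy. No step beyond the scatter is therefore expected in this assay.

Compound 3 is estimated at 3000000 nM, with a range from 1000000 nM to 9000000 nM, an expected step of a 1.1-fold lower number from compound 2 to compound 3 (0.04 log units; within the scatter).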

Compound 3, concentration for 50% growth inhibition: 4800000 nM
Compound 3: the middle estimate sits 1.6-fold (0.20 log units) below what was measured, within the range that was stated.
By their numbers in this assay, from the lowest: compounds 1, 2 and 3 (each within the scatter of the next, the first and the last beyond it).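

Placing methoxy instead of fluoro on the aromatic carbon para to a large group gives a 1.5-fold higher number from compound 2 to compound 3 (0.16 log units; within the scatter), so in this assay the 4-fluorophenyl and 4-methoxyphenyl compounds cannot be told apart. For the compounds shown here, measured against hydrogen at the same place, however, methoxy gives a 2.4-fold higher number from compound 1 to compound 3 (0.38 log units; beyond the scatter), the first step here to pass the scatter, and it is a modest move towards weaker inhibition of growth. Nothing measured here speaks to the reason for this step.

As far as these compounds go, whether an amine, a carboxylic acid or a longer chain such as ethoxy at this position would bring the numbers down to stronger inhibition of growth remains open. Also open, from the compounds shown here alone, is whether the step from hydrogen to methoxy would repeat on a different core.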